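From 2-carboxyphenyl to 4-nitrophenyl

The source may report more compounds than this note shows. Statements on the series, on what has been measured and on what is new or still open speak of the compounds shown alone.

Compound 3 (`O=C(O)c1ccccc1COc1ccc(OCCOCCNC2CCCC2)cc1`) stands at > 100000 nM in a functional assay on SK-OV-3 cells (Homo sapiens) for inhibition, read by CCK-8 assay, with a stated time of 70 h (on this read-out lower numbers stand for stronger inhibition and higher numbers for weaker inhibition), as a limit and not a number. Among the measured compounds shown here, that is the limit of > 100000 nM in this assay, at which 1 of the 3 values shown sits, and no step from it has been measured. Compound 4 (`O=[N+]([O-])c1ccc(COc2ccc(OCCOCCNC3CCCC3)cc2)cc1`) has 4-nitrophenyl in place of 2-carboxyphenyl on a saturated chain carbon bound to an oxygen on an aromatic ring. For the measured compounds named here, no measured step covers this change: the only one, a 1.8-fold lower number from compound 1 to compound 2 (0.26 log units; within the scatter) and so within the scatter, concerns an amine nitrogen. Still, compound 1 (`c1ccc(COc2ccc(OCCOCCNc3ccncc3)cc2)cc1`) at 20600 nM and compound 2 (`c1ccc(COc2ccc(OCCOCCNc3cc[nH]c3)cc2)cc1`) at 11300 nM carry no 2-carboxyphenyl and give numbers rather than a limit. A lower number is therefore expected, with an at least 6.6-fold lower number from compound 3 to compound 4 (0.82 log units; beyond the scatter) as the estimated step. Compound 4 is estimated at 15000 nM in this assay with 4000 nM to 60000 nM as the expected range.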

Compound 4, half-maximal inhibitory concentration: 20300 nM
For compound 4 the middle estimate is 1.4-fold (0.13 log units) below the measured one; the measured number falls inside the stated range.
By their numbers in this assay, from the lowest: compounds 2, 4 and 1 (each within the scatter of the next). At a limit, above all of these: compound 3.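

In this assay, 4-nitrophenyl in place of 2-carboxyphenyl on a saturated chain carbon bound to an oxygen on an aromatic ring gives an at least 4.9-fold lower number from compound 3 to compound 4 (0.69 log units; beyond the scatter). Among the compounds shown here, this is the first measured change at this place, and it turns a limit into a number for the shared core. Compound 3 has only a limit, so the full size of the step cannot be read: the limit of > 100000 nM in this assay, at which 1 of the 4 values shown sits.

The compounds shown leave open whether a methyl ester, a primary amide or a plain phenyl in that place would give a number or a limit. They also do not separate the removal of the carboxylic acid from the addition of the nitro group.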